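One Swap, Two Cores: Expecting the Lipophilicity of Compound 4

The source may hold more compounds than are shown below. What is called first, only, known or untested is meant among the compounds shown, and "the series" means these compounds.

Compound 1 `O=C1/C(=C/c2ccc(Cl)cc2)CCC/C1=C\c1ccc([N+](=O)[O-])cc1` and compound 2 `CN(C)c1ccc(/C=C2\CCC/C(=C\c3ccc([N+](=O)[O-])cc3)C2=O)cc1` share a core and differ in one place: dimethylamino in place of chloro on an aromatic carbon. In a physicochemical assay for lipophilicity (a lower number here means a more polar compound, a higher number a more lipophilic compound), compound 1 gives 5.08 and compound 2 gives 5.08, so the step reads no change at the digits printed from compound 1 to compound 2 (within the scatter). Compound 3 `O=C1/C(=C/c2ccc(Cl)cc2)CCC/C1=C\c1cccc([N+](=O)[O-])c1` is built from the same atoms as compound 1, joined differently; the difference between the two cores is not broken down here. In this assay compound 3 gives 5.06. Compound 4 `CN(C)c1ccc(/C=C2\CCC/C(=C\c3cccc([N+](=O)[O-])c3)C2=O)cc1` has not yet been measured. It differs from compound 3 by dimethylamino in place of chloro on an aromatic carbon, the same change seen between compound 1 and compound 2, at the same kind of place. Because no change at the digits printed from compound 1 to compound 2 (within the scatter), the expected step is no change at the digits printed from compound 3 to compound 4 (within the scatter). Compound 4 is therefore estimated at 5.06 in this assay, between 4.76 and 5.36.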

Compound 4, partition coefficient: 5.06
For compound 4 middle estimate and measured number coincide at the digits printed, within the range that was stated.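

In this assay the swap of chloro for dimethylamino reads the same in both cores (no change at the digits printed from compound 1 to compound 2 (within the scatter)) and (no change at the digits printed from compound 3 to compound 4 (within the scatter)). Putting 3-nitrophenyl in place of 4-nitrophenyl also stays within the scatter (a number 0.02 log units lower from compound 2 to compound 4 (within the scatter)), so neither change moves the reading among these four compounds. This shows that the swap carried over between this one pair of cores, but it does not show that it would carry over to any other core, and no measurement here accounts for the level numbers.

The compounds shown leave open whether a carboxylic acid or a longer chain in the place of chloro would leave the number just as level. They also leave open whether the swap reads the same when an amine replaces the nitro group.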